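Open Chain in Place of Pentylphenyl: Series Notes

The compounds below may be only part of what the source reports. "The series", "measured", "known", "first", "only" and "open" are said of these compounds alone.

Measured so far in a functional assay on A549 cells (Homo sapiens) for antiproliferative activity, read by MTT assay, with a stated time of 72 h; on this read-out lower numbers stand for stronger inhibition and higher numbers for weaker inhibition:
compound 1, `Cc1ccc(S(=O)(=O)NCc2cn(C[C@H](O)[C@H]3OC(=O)C(OCc4ccccc4)=C3OCc3ccccc3)nn2)cc1`, gives 16800 nM;
compound 2, `O=C1O[C@H]([C@@H](O)Cn2cc(CNS(=O)(=O)c3ccc(Cl)cc3F)nn2)C(OCc2ccccc2)=C1OCc1ccccc1`, gives 39100 nM;
compound 3, `CCCCCc1ccc(-c2cn(C[C@H](O)[C@H]3OC(=O)C(OCc4ccccc4)=C3OCc3ccccc3)nn2)cc1`, gives 6220 nM.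

Compound 3 stands lowest of the three measured values, with compound 1 nearest and compound 2 furthest off. Among the compounds with values here, the two single-point steps so far are a 2.7-fold lower number from compound 1 to compound 3 (0.43 log units; beyond the scatter) and a 2.3-fold higher number from compound 1 to compound 2 (0.37 log units; beyond the scatter), both modest but beyond the scatter.

Compound 4, `CCCCCCCCCCc1cn(C[C@H](O)[C@H]2OC(=O)C(OCc3ccccc3)=C2OCc2ccccc2)nn1`, is the next point: decyl in place of 4-pentylphenyl on an aromatic carbon. The group that leaves carries one six-membered aromatic ring of carbon only; the group that enters has no ring.

Of the measured steps, only a 2.7-fold lower number from compound 1 to compound 3 (0.43 log units; beyond the scatter) touches this aromatic carbon, and it exchanged a sulfonamide-bearing group for the aryl, not an aryl for a chain. The step of a 2.3-fold higher number from compound 1 to compound 2 (0.37 log units; beyond the scatter) sits on the sulfonyl sulfur and does not bear on this change. Within the data shown here, no step in the set exchanges a ring for an open chain at this position. A step of modest size at most is therefore expected in this assay, with the direction uncertain.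

For compound 4 the expected value is 8000 nM, estimated to fall between 3000 nM and 22000 nM. This amounts to an expected 1.3-fold higher number from compound 3 to compound 4 (0.11 log units; within the scatter).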

Compound 4, half-maximal inhibitory concentration: 6750 nM
Compound 4: the middle estimate sits 1.2-fold (0.07 log units) above what was measured; low and high end bracket the measured number.
By their numbers in this assay, from the lowest: compounds 3 and 4 (each within the scatter of the next); then compound 1; then compound 2.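

In this assay, within the data shown here, the aromatic ring of 4-pentylphenyl is not required at this aromatic carbon: with decyl in its place there is a 1.1-fold higher number from compound 3 to compound 4 (0.04 log units; within the scatter), the first ring-to-open-chain exchange at this position. The sulfonamide compounds remain apart from the decyl compound, with a 2.5-fold lower number from compound 1 to compound 4 (0.40 log units; beyond the scatter) and a 5.8-fold lower number from compound 2 to compound 4 (0.76 log units; beyond the scatter), so nonyl in place of either sulfonylamino group on the saturated chain carbon gives a lower number in both pairs. No available evidence accounts for these results.

Still open, on these data alone, is how the number responds at this aromatic carbon to a shorter chain such as hexyl, a longer chain such as hexadecyl, or a chain carrying an amine or a carboxylic acid. Also open, as far as these compounds go, is whether the match between the pentylphenyl and decyl compounds holds when the benzyl groups of the shared core give way to hydrogen.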